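Halogen to Methyl on the Aryl Amide: T47D Growth Inhibition

This account rests on a few compounds, and the source may have more. Where it says the series, first, only, none or still open, it means among the compounds named here.

Measured compounds:
compound 1, `CN(C)C(=O)c1cc2cnc(Nc3ccc(NC(=O)C4(C(=O)Nc5ccc(Br)cc5)CC4)cc3)nc2n1C1CCCC1`: 94.3%
compound 2, `CN(C)C(=O)c1cc2cnc(Nc3ccc(NC(=O)C4(C(=O)Nc5cccc(Cl)c5)CC4)cc3)nc2n1C1CCCC1`: 92.6%
compound 3, `CN(C)C(=O)c1cc2cnc(Nc3ccc(NC(=O)C4(C(=O)Nc5cccc(Br)c5)CC4)cc3)nc2n1C1CCCC1`: 94.6%

All three were tested in a functional assay on T47D cells (Homo sapiens) for inhibition, read by CCK-8 assay, with a stated time of 72 h, tested at 10 uM; on this read-out higher numbers stand for more inhibition of growth at the one concentration tested and lower numbers for less inhibition of growth. Compound 3 gives the highest of the three numbers, but its lead is small: a number 0.3 percentage points higher from compound 1 to compound 3 (within the scatter) and a number 2 percentage points higher from compound 2 to compound 3 (within the scatter) both fall within the scatter, so the three compounds cannot be told apart on these readings. The same holds for a number 1.7 percentage points lower from compound 1 to compound 2 (within the scatter).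

Compound 4, `Cc1ccc(NC(=O)C2(C(=O)Nc3ccc(Nc4ncc5cc(C(=O)N(C)C)n(C6CCCC6)c5n4)cc3)CC2)cc1`, has not been measured. It differs from compound 3 in one place: 4-methylphenyl in place of 3-bromophenyl on an amide-type nitrogen. The measured steps bear on this only loosely. They show that moving a halogen around the ring, or exchanging one halogen for another, leaves the number essentially unchanged, and every measured compound sits close to complete inhibition. None of the steps removes the halogen or brings in a methyl group, so a direct precedent is lacking. Given how insensitive this position has been, compound 4 is expected to stay near its neighbours, with a step of a number 4.6 percentage points lower from compound 3 to compound 4 (within the scatter) that should not exceed the scatter. Compound 4 is therefore estimated at 90%, within 78% to 97%.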

Compound 4, percent growth inhibition at one concentration: 99.6%
The estimate for compound 4 lay 9.6 percentage points below the measured number; measured number above the stated range.
By their numbers in this assay, from the lowest: compounds 2, 1, 3 and 4 (each within the scatter of the next).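

For the compounds shown here, this is the first change on the aryl amide that takes the halogen away altogether, and in this assay the readings show no loss of growth inhibition with a methyl group on the ring. The direct swap of methyl for bromo on an aromatic carbon gives a number 5.3 percentage points higher from compound 1 to compound 4 (within the scatter) and the swaps of 4-methylphenyl for 3-bromophenyl and for 3-chlorophenyl give a number 5 percentage points higher from compound 3 to compound 4 (within the scatter) and a number 7 percentage points higher from compound 2 to compound 4 (within the scatter) so among these compounds a halogen is not needed on this ring. No supporting measurement is available to explain these readings.

Groups on this ring that are neither halogen nor methyl, such as an amine or a carboxylic acid, remain open, as does a longer chain in place of the methyl. On these data alone, with every reading close to complete inhibition at the one concentration tested, it also remains open whether these compounds would separate at lower concentrations.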